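Chloro in place of bromo: notes toward compound 3

The compounds below may be only part of what the source reports. "The series", "measured", "known", "first", "only" and "open" are said of these compounds alone.

Measured so far:
compound 1 `CN(C)c1ccc(C2CC(c3ccccc3)=NN2C2=NC(=O)/C(=C3\C(=O)Nc4ccccc43)S2)cc1` gives 25200 nM in a functional assay on cells (Cancer cell lines, Homo sapiens) for cytotoxicity, read by sulforhodamine B assay, with a stated time of 48 h; on this read-out higher numbers stand for weaker inhibition of growth and lower numbers for stronger inhibition of growth
compound 2 `CN(C)c1ccc(C2CC(c3ccccc3)=NN2C2=NC(=O)/C(=C3\C(=O)Nc4ccc(Br)cc43)S2)cc1` gives 540 nM in this assay

Going by the values given here, compound 2 holds the lowest of the two numbers in this assay; its only neighbour is compound 1, and the gap is a 47-fold lower number from compound 1 to compound 2 (1.67 log units; beyond the scatter), a large step beyond the scatter. Among the compounds with values here, that step is bromo in place of hydrogen on an aromatic carbon, and it is the only measured change at that site.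

Compound 3 `CN(C)c1ccc(C2CC(c3ccccc3)=NN2C2=NC(=O)/C(=C3\C(=O)Nc4ccc(Cl)cc43)S2)cc1` differs from compound 2 by chloro in place of bromo on an aromatic carbon. Within the data shown here, the step from compound 1 to compound 2 bears on this only indirectly: it shows that a halogen at this carbon goes with a low number in this assay, but no measured pair swaps one halogen for another, so the size of a bromo-to-chloro exchange is unknown here. The expectation is a step near or within the scatter, leaning if anything toward a somewhat higher number. Compound 3 is therefore estimated at 800 nM in this assay, with a range of 300 nM to 2500 nM. The expected step is a 1.5-fold higher number from compound 2 to compound 3 (0.17 log units; within the scatter).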

Compound 3, concentration for total growth inhibition: 510 nM
Compound 3: middle estimate off by 1.6-fold (0.20 log units), on the high side, within the range that was stated.
By their numbers in this assay, from the lowest: compounds 3 and 2 (each within the scatter of the next); then compound 1.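

Going by these compounds alone, the first direct exchange of one halogen for another at this aromatic carbon gives a 1.1-fold lower number from compound 2 to compound 3 (0.02 log units; within the scatter) in this assay, so bromo and chloro cannot be told apart on this read-out. Chloro in place of hydrogen gives a 49-fold lower number from compound 1 to compound 3 (1.69 log units; beyond the scatter) and stands as a second large step alongside a 47-fold lower number from compound 1 to compound 2 (1.67 log units; beyond the scatter) for bromo, so the large change at this carbon no longer rests on bromo alone but is seen with two halogens. No supporting data bear on what lies behind this shared result, and the numbers record only that the two halogens go with values that lie within the scatter of each other.

Still open, going by these compounds, is whether a halogen is needed at all, since a methyl, a methoxy or a nitrile on the same carbon would show whether groups other than halogens also go with a low number, and fluoro would extend the halogen comparison. Also open is whether the match between bromo and chloro holds on the other aromatic carbons of this six-membered ring, where neither halogen appears in the compounds shown.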